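A few compounds are considered here, and "the series" means these few. Any claim that something is new, unique, unknown or untested is made for them only; others in the source may bear on it.

Compound 3, with the structure `CCCOC(=O)C(O)Cn1cnc2c(N)ncnc21`, is tested for its effect on cells in a functional assay on HeLa cells (Homo sapiens) for cytotoxicity; a higher number here means that more compound is tolerated, a lower number that less compound is tolerated. In this assay compound 3 gives > 400 ug/mL, which is a limit of the assay rather than a number. Compound 1, `CCCCOC(=O)C(O)Cn1cnc2c(N)ncnc21`, gives 400 ug/mL in this assay. Compound 2, `CC(C)OC(=O)C(O)Cn1cnc2c(N)ncnc21`, gives > 400 ug/mL, again a limit. The steps of a number no lower from compound 1 to compound 3 (the limit leaves the size open) and a step that the two limits leave unreadable from compound 2 to compound 3 therefore read as no lower or unreadable, with two of three values resting at the limit of > 400 ug/mL in this assay, at which 2 of the 3 values shown sit. Compound 4, `CCOC(=O)C(O)Cn1cnc2c(N)ncnc21`, differs from compound 3 by hydrogen in place of methyl on a saturated chain carbon, two bonds along the chain from an oxygen next to a carbonyl group. Because the shortening by one carbon in a number no lower from compound 1 to compound 3 (the limit leaves the size open) brought no fall, compound 4 is expected to give about 400 ug/mL, within 200 ug/mL to 800 ug/mL, an expected step of a number no higher from compound 3 to compound 4 (the limit leaves the size open).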

Compound 4, minimum cytotoxic concentration: > 400 ug/mL
Compound 4 was reported as a limit; the forecaster's own chance of this, stated with the estimate: 65%; the middle value sits exactly at the limit.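

Taking the chain from propoxy to ethoxy gives no readable fall in this assay, as compound 4 also rests at a limit. Set against the butyl chain, the result is a number no lower from compound 1 to compound 4 (the limit leaves the size open). The steps to compound 4 from compound 2 and from compound 3 cannot be read, and the series now sits largely at one ceiling: the limit of > 400 ug/mL in this assay, at which 3 of the 4 values shown sit.

The compounds shown leave open where the true values of compound 2, compound 3 and compound 4 lie. They also leave open whether a longer chain such as hexyl, or a carboxylic acid in place of the alkoxy group, would change the tolerated amount.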